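Hydroxy for bromo on the pendant aryl ring

The compounds below may be only part of what the source reports. "The series", "measured", "known", "first", "only" and "open" are said of these compounds alone.

The compounds share one core carrying two aryl groups and differ only in the second of them. Compound 1 `COc1ccc(-c2nc3cccc(-c4cc(OC)c(OC)c(OC)c4)c3o2)cc1` gives only a limit in a functional assay on U-251 cells (Homo sapiens) for antiproliferative activity, read by MTT assay, with a stated time of 48 h (on this read-out higher numbers stand for weaker inhibition and lower numbers for stronger inhibition), > 25000 nM; this is the limit of > 25000 nM in this assay, at which 1 of the 3 values shown sits. Compound 2 `COc1ccc(-c2nc3cccc(-c4cc(OC)c(OC)c(OC)c4)c3o2)cc1OC` gives 1300 nM in this assay, and compound 3 `COc1cc(-c2cccc3nc(-c4cccc(Br)c4)oc23)cc(OC)c1OC` gives 6800 nM. Among the two numbers compound 3 stands highest, separated from compound 2 by a 5.2-fold higher number from compound 2 to compound 3 (0.72 log units; beyond the scatter); the steps of an at least 19-fold lower number from compound 1 to compound 2 (1.28 log units; beyond the scatter) and an at least 3.6-fold lower number from compound 1 to compound 3 (0.56 log units; beyond the scatter) both start from the limit and so give lower bounds only.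

Compound 4 `COc1cc(-c2cccc3nc(-c4cccc(O)c4)oc23)cc(OC)c1OC` differs from compound 3 by hydroxy in place of bromo on an aromatic carbon. Among the compounds with values here, no measured step exchanges bromo for hydroxy, so nothing here bears directly on this change. The steps that alter the same ring, an at least 3.6-fold lower number from compound 1 to compound 3 (0.56 log units; beyond the scatter) and a 5.2-fold higher number from compound 2 to compound 3 (0.72 log units; beyond the scatter), show that a substituent on it can move the number by a modest amount in either direction. A step of comparable size is therefore expected, with neither direction clearly favoured; the estimated step is a 1.4-fold lower number from compound 3 to compound 4 (0.13 log units; within the scatter), small enough that its direction should not be read as settled. For compound 4 the expected value in this assay is 5000 nM, within a range from 1500 nM to 20000 nM.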

Compound 4, half-maximal inhibitory concentration: 5500 nM
Compound 4: middle estimate off by 1.1-fold (0.04 log units), on the low side, within the range that was stated.
By their numbers in this assay, from the lowest: compound 2; then compounds 4 and 3 (each within the scatter of the next). At a limit, above all of these: compound 1.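

In this assay, the exchange on the aromatic carbon meta to a large group gives a 1.2-fold lower number from compound 3 to compound 4 (0.09 log units; within the scatter), so bromo and hydroxy cannot be told apart at this place, even though hydroxy brings one hydrogen-bond donor and one hydrogen-bond acceptor that bromo lacks. With 3-hydroxyphenyl as with 3-bromophenyl, the distance to the 3,4-dimethoxyphenyl group stays beyond the scatter, at a 4.2-fold higher number from compound 2 to compound 4 (0.63 log units; beyond the scatter), and compound 2 keeps the lowest number of the four. The step of an at least 4.5-fold lower number from compound 1 to compound 4 (0.65 log units; beyond the scatter) gives a second 3-substituted phenyl group clear of the 4-methoxyphenyl group, but it is a lower bound only, and compound 1 remains a limit: the limit of > 25000 nM in this assay, at which 1 of the 4 values shown sits.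

Still open, going by these compounds, is whether a single methoxy at this place, without the second methoxy of compound 2, would account for the lower number of compound 2. Also open, on these data alone, is whether an amine or a carboxylic acid on the same carbon would sit level with bromo and hydroxy or move the number away from them.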